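The source may report more compounds than this note shows. Statements on the series, on what has been measured and on what is new or still open speak of the compounds shown alone.

Compound 3 `CC(=O)OC[C@H]1CN(c2ccc(-n3cc(-c4ccccn4)cn3)c(F)c2)C(=O)O1` gives the highest number of the three compounds in a physicochemical assay for solubility, read by HPLC, with a stated time of 24 h (on this read-out lower numbers stand for lower solubility and higher numbers for higher solubility), at 373000 nM. Compound 1 `O=C1O[C@@H](CO)CN1c1ccc(-n2cc(-c3ccccn3)cn2)c(F)c1` gives 56400 nM, and compound 2 `COC(=O)CC1CCN(C[C@H]2CN(c3ccc(-n4cc(-c5ccccn5)cn4)c(F)c3)C(=O)O2)CC1` gives 92100 nM. The step to compound 4 `O=C1O[C@@H](Cn2ccnn2)CN1c1ccc(-n2cc(-c3ccccn3)cn2)c(F)c1` is 1H-1,2,3-triazol-1-yl in place of acetoxy on a saturated chain carbon bound to a saturated ring carbon. Among the compounds with values here, two measured steps bear on it, each ending at compound 3 and its acetoxy group: a 6.6-fold higher number from compound 1 to compound 3 (0.82 log units; beyond the scatter) and a 4.0-fold higher number from compound 2 to compound 3 (0.61 log units; beyond the scatter). In both, the acetoxy compound stood beyond the scatter above its partner, so a change that removes acetoxy is expected to lower the number in this assay by a modest step, a 4.1-fold lower number from compound 3 to compound 4 (0.62 log units; beyond the scatter). Compound 4 is therefore expected to give 90000 nM in this assay, with a range from 30000 nM to 270000 nM.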

Compound 4, solubility: 247000 nM
Beside the measured number, compound 4's estimate is 2.7-fold (0.44 log units) below it, within the range that was stated.
By their numbers in this assay, from the lowest: compounds 1 and 2 (each within the scatter of the next); then compounds 4 and 3 (each within the scatter of the next).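

At this saturated chain carbon bound to a saturated ring carbon, 1H-1,2,3-triazol-1-yl reads much like acetoxy in this assay, with a 1.5-fold lower number from compound 3 to compound 4 (0.18 log units; within the scatter), so the high number is not tied to acetoxy alone. The same group stands clear of the hydroxy and piperidinyl compounds, with a 2.7-fold higher number from compound 2 to compound 4 (0.43 log units; beyond the scatter) and with a 4.4-fold higher number from compound 1 to compound 4 (0.64 log units; beyond the scatter). No measured evidence accounts for this result. From the compounds shown here alone, whether an amine or a carboxylic acid on this chain carbon would give a similar number remains open.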